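Aryl for benzyl on the amine of compound 2

The source may hold more compounds than are shown below. What is called first, only, known or untested is meant among the compounds shown, and "the series" means these compounds.

Measured compounds and their numbers:
Compound 1, `O=C1C(Nc2ccc(I)cc2)=CC(=O)c2c1nc1n2[C@H]2OC[C@@H](O)[C@H]2OC1`: 2150 nM
Compound 2, `O=C1C=C(NCc2ccccc2)C(=O)c2c1nc1n2[C@H]2OC[C@@H](O)[C@H]2OC1`: 2670 nM
Compound 3, `O=C1C(Nc2ccc(C(F)(F)F)cc2)=CC(=O)c2c1nc1n2[C@H]2OC[C@@H](O)[C@H]2OC1`: 1860 nM

In a functional assay on MGC-803 cells (Homo sapiens) for inhibition, read by sulforhodamine B assay (on this read-out lower numbers stand for stronger inhibition and higher numbers for weaker inhibition), compound 2 gives 2670 nM. The nearest number among the measured compounds is that of compound 1, the furthest that of compound 3, and both gaps lie within the scatter, so none of these three compounds is set apart from another on this read-out.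

Compound 4, `Cc1ccc(NC2=CC(=O)c3nc4n(c3C2=O)[C@H]2OC[C@@H](O)[C@H]2OC4)cc1`, has not been measured. It differs from compound 2 as follows: 4-methylphenyl in place of benzyl on an amine nitrogen. For the measured compounds named here, the only single-point step among the measured compounds is a 1.2-fold lower number from compound 1 to compound 3 (0.06 log units; within the scatter), an exchange of one substituent on the aryl ring of an arylamino compound; it does not touch the benzylamino to arylamino change itself. What the data do show is that the two arylamino compounds, compound 1 with 2150 nM and compound 3 with 1860 nM, sit within the scatter of compound 2.

Compound 4 is therefore expected to give about 2000 nM (range 900 nM to 4500 nM). The expected step of a 1.3-fold lower number from compound 2 to compound 4 (0.13 log units; within the scatter) lies within the scatter.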

Compound 4, half-maximal inhibitory concentration: 1420 nM
Compound 4: middle estimate off by 1.4-fold (0.15 log units), on the high side; the measured number falls inside the stated range.
By their numbers in this assay, from the lowest: compounds 4, 3, 1 and 2 (each within the scatter of the next).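

For the compounds shown here, the exchange of benzyl for 4-methylphenyl on the amine nitrogen gives the first direct reading of the benzylamino to arylamino change: in this assay it gives a 1.9-fold lower number from compound 2 to compound 4 (0.27 log units; within the scatter) and so does not set the two compounds apart. The earlier compounds shown here compared only one aryl substituent with another, whereas this pair shows that replacing benzyl with an aryl group of the same heavy-atom count leaves the number within the scatter at this position. Nothing measured here explains the size of this step.

The compounds shown leave open whether a group of a different kind on this amine nitrogen, such as a pyridine ring, a morpholine or a longer chain such as phenethyl, would move the number beyond the scatter. On these data alone, it also remains open whether a carboxylic acid or an amine on the aryl ring would do so.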